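The source may report more compounds than this note shows. Statements on the series, on what has been measured and on what is new or still open speak of the compounds shown alone.

Measured compounds in a functional assay on B16 cells (Mus musculus) for inhibition; on this read-out lower numbers stand for stronger inhibition and higher numbers for weaker inhibition:
compound 1, `Cc1ccc(/C=N/NC(N)=S)cc1`, gives 6800 nM
compound 2, `Cc1cccc(/C=N/NC(N)=S)c1`, gives 2800 nM

Compound 2 stands lowest of these two numbers in this assay; the gap to compound 1 lies beyond the scatter. Compound 3, `NC(=S)N/N=C/c1cccc(Cl)c1`, has not yet been measured in this assay. It differs from compound 2 by chloro in place of methyl on an aromatic carbon. For the measured compounds named here, no step between measured compounds covers such an exchange, so no measured step size guides this one. The expected step, a 1.4-fold lower number from compound 2 to compound 3 (0.15 log units; within the scatter), is small and downward, not beyond the scatter. For compound 3 the estimate in this assay is 2000 nM, in a range from 700 nM to 6000 nM.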

Compound 3, half-maximal inhibitory concentration: 2400 nM
Beside the measured number, compound 3's estimate is 1.2-fold (0.08 log units) below it; low and high end bracket the measured number.
By their numbers in this assay, from the lowest: compounds 3 and 2 (each within the scatter of the next); then compound 1.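

Compounds 1 and 2 both carry methyl, so they said nothing about the group itself at this place. In this assay, chloro in place of methyl on an aromatic carbon, meta to a group of 6 heavy atoms, gives a 1.2-fold lower number from compound 2 to compound 3 (0.07 log units; within the scatter), so at this place the read-out does not tell the two groups apart. Nothing measured on these compounds offers a reason for this. On these data alone, whether an amine, a carboxylic acid or a longer chain at this place would keep the number in this range stays open. So does whether chloro would match methyl at the place it occupies in compound 1.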